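A few compounds are considered here, and "the series" means these few. Any claim that something is new, unique, unknown or untested is made for them only; others in the source may bear on it.

Series notes. Compound 1 `CC(Oc1ccc(Oc2ccc(F)cc2)cc1)C(=O)Cn1nnc(-c2ccc(Cl)cc2)n1` and compound 2 `CC(Oc1ccc(Oc2ccc(Cl)cc2)cc1)C(=O)Cn1nnc(-c2ccc(Cl)cc2)n1` share one core and differ by chloro in place of fluoro on an aromatic carbon. In a physicochemical assay for lipophilicity, read by HPLC, tested at 5 mM (on this read-out lower numbers stand for lower lipophilicity and higher numbers for higher lipophilicity), compound 1 gives 6.2, and compound 2 gives 6.8, a step of a number 0.60 log units higher from compound 1 to compound 2 (beyond the scatter). Compound 3 `CC(Oc1ccc(Oc2ccc(F)cc2)cc1)C(=O)Cn1nnc(-c2ccc(C(=O)O)cc2)n1` differs from compound 1 by carboxy in place of chloro on an aromatic carbon; in this assay compound 3 gives 2.7, the lowest of the three, with a step of a number 3.50 log units lower from compound 1 to compound 3 (beyond the scatter). Compound 4 `CC(Oc1ccc(Oc2ccc(Cl)cc2)cc1)C(=O)Cn1nnc(-c2ccc(C(=O)O)cc2)n1` has not yet been measured in this assay. It differs from compound 3 by chloro in place of fluoro on an aromatic carbon, the same change as from compound 1 to compound 2, at the same place, while the two cores differ as noted above. The step from compound 3 to compound 4 is expected to be a number 0.60 log units higher from compound 3 to compound 4 (beyond the scatter), resting on the step of a number 0.60 log units higher from compound 1 to compound 2 (beyond the scatter) seen for the same change. Compound 4 is thus expected to give about 3.3 in this assay, between 2.9 and 3.7.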

Compound 4, partition coefficient: 3.3
Compound 4: the middle estimate sits on the measured number at the digits printed; the measured number falls inside the stated range.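

In this assay the chloro-for-fluoro change gives a number 0.60 log units higher from compound 3 to compound 4 (beyond the scatter), the same size as a number 0.60 log units higher from compound 1 to compound 2 (beyond the scatter), so in this pair of cores the step carries over unchanged. The carboxy-for-chloro change agrees in the same way, with a number 3.50 log units lower from compound 2 to compound 4 (beyond the scatter) matching a number 3.50 log units lower from compound 1 to compound 3 (beyond the scatter), and the four compounds therefore fit two independent steps. This rests on one place and two cores only, shows nothing about other cores, and no measurement shown explains the agreement.

Going by these compounds, whether the step holds on a core carrying an amine or a longer chain in place of the carboxy group stays open. Also open, on these data alone, is whether a bromo or a methoxy group in that same place would carry over as closely.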